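A Methyl Added to the Sulfonyl Ring of Compound 3

The compounds below may be only part of what the source reports. "The series", "measured", "known", "first", "only" and "open" are said of these compounds alone.

Compound 1 `Cc1ccc(S(=O)(=O)NC(=O)/C=C/c2ccccc2)cc1`: 13.8 ug/mL
Compound 2 `Cc1ccc(S(=O)(=O)NC(=O)/C=C/c2ccc(F)cc2)cc1`: 4.8 ug/mL
Compound 3 `O=C(/C=C/c1ccc(Cl)cc1)NS(=O)(=O)c1ccccc1`: 2.2 ug/mL

In a functional assay on B16-F10 cells (Mus musculus) for antiproliferative activity, read by ELISA and MTT assay, with a stated time of 48 h (a higher number here means a weaker inhibitor, a lower number a stronger inhibitor), compound 3 gives 2.2 ug/mL, the lowest of the three numbers; compound 2 stands nearest with 4.8 ug/mL, and compound 1 stands furthest with 13.8 ug/mL. Compound 4 `Cc1ccc(S(=O)(=O)NC(=O)/C=C/c2ccc(Cl)cc2)cc1` differs from compound 3 by methyl in place of hydrogen on an aromatic carbon. Within the data shown here, the only measured step, a 2.9-fold lower number from compound 1 to compound 2 (0.46 log units; beyond the scatter), concerns a different change on the other ring and gives no direct guidance on a methyl. Among the measured compounds shown here, with no measured step touching this change, the expectation is a step no larger than the scatter, no change at the digits printed from compound 3 to compound 4 (within the scatter), in either direction. Compound 4 is therefore estimated at 2.2 ug/mL, within a range of 1 ug/mL to 4.8 ug/mL.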

Compound 4, half-maximal inhibitory concentration: 4.6 ug/mL
Compound 4: the middle estimate sits 2.1-fold (0.32 log units) below what was measured; the range from low to high includes it.
By their numbers in this assay, from the lowest: compound 3; then compounds 4 and 2 (each within the scatter of the next); then compound 1.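

In this assay the phenyl to 4-methylphenyl change is not silent, since methyl in place of hydrogen gives a 2.1-fold higher number from compound 3 to compound 4 (0.32 log units; beyond the scatter) and so moves the number away from the lowest value. With the methyl in place, chloro in place of fluoro gives a 1.0-fold lower number from compound 2 to compound 4 (0.02 log units; within the scatter) and chloro in place of hydrogen gives a 3.0-fold lower number from compound 1 to compound 4 (0.48 log units; beyond the scatter), so both halogens stand apart from hydrogen but not from each other. Nothing at hand explains the methyl step. Going by these compounds, whether a methoxy group or an amine at that position would behave like the methyl remains open.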